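The compounds below may be only part of what the source reports. "The series", "measured", "known", "first", "only" and "open" are said of these compounds alone.

Measured in an ADME assay on RAW264.7 cells (Mus musculus) for cytotoxicity, read by MTT assay, with a stated time of 24 h, tested at 1.25 ug/mL; on this read-out lower numbers stand for a stronger effect and higher numbers for a weaker effect at the one concentration tested:
compound 1 `COc1ccc(/C=C/C(=O)c2ccc(OC)c(OC)c2)cc1` — 97.2%
compound 2 `COc1ccc(C(=O)/C=C/c2ccc(OC)c(OC)c2OC)c(O)c1` — 98.5%
compound 3 `COc1ccc(/C=C/C(=O)c2cccc(O)c2)c(OC)c1` — 97.7%

The three numbers lie within the usual scatter of one another, so compound 1 stands level with compound 3 and with compound 2; nothing separates them in this assay. All three leave the cells largely intact at the one concentration tested.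

Compound 4 `COc1ccc(/C=C/C(=O)c2ccc(OC)c(OC)c2)cc1OC` has not been measured. It differs from compound 1 by methoxy in place of hydrogen on an aromatic carbon. For the measured compounds named here, no step between measured compounds involves such a change, so there is no measured step to lean on. Given that compound 1, compound 2 and compound 3 all sit close together in this assay, no step beyond the scatter is expected from compound 1 to compound 4, in either direction. The expected step is a number 0.2 percentage points lower from compound 1 to compound 4 (within the scatter). Compound 4 is estimated at 97%, between 91% and 101%.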

Compound 4, a percentage reported as activity, at one concentration (the size of the read-out at that concentration, not a potency): 94%
Compound 4: middle estimate off by 3 percentage points, on the high side; measured number inside the range.
By their numbers in this assay, from the lowest: compounds 4, 1, 3 and 2 (each within the scatter of the next).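

In this assay, for the compounds shown here, methoxy in place of hydrogen on an aromatic carbon, ortho to a methoxy group, gives a number 3.2 percentage points lower from compound 1 to compound 4 (within the scatter), the first step that can be read at a single place. This position therefore accepts the added methoxy without a step beyond the scatter at the one concentration tested. No measured evidence bears on this result.

On these data alone, whether an amine or a carboxylic acid at this position would also stay within the scatter remains open. So does the effect of removing the neighbouring methoxy group.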